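The source may report more compounds than this note shows. Statements on the series, on what has been measured and on what is new or still open speak of the compounds shown alone.

Compound 1, `CSc1nc(NCCCc2ccccc2)c2ccccc2n1`, gives 19600 nM in a functional assay on HT-29 cells (Homo sapiens) for cytotoxicity, read by MTT assay, with a stated time of 72 h; on this read-out lower numbers stand for stronger inhibition of growth and higher numbers for weaker inhibition of growth.
Compound 2, `CSc1nc(NCc2ccccc2)c2ccccc2n1`, gives 36500 nM in this assay.

Both of these numbers are large, which on this read-out means only weak inhibition of growth. The gap between compound 2 and compound 1 lies within the usual scatter of repeated measurements, so on these data the two compounds cannot be told apart.

Compound 3, `CSc1nc(NCCCCCO)c2ccccc2n1`, has not yet been measured. It differs from compound 2 in one place: 4-hydroxybutyl in place of phenyl on a saturated chain carbon bound to a nitrogen on an aromatic ring. Among the compounds with values here, no measured pair of compounds shows what such a change does in this assay, so the expectation can rest only on the two weak values already in hand, which share the same core and differ merely in the length of the saturated chain. For compound 3 the expected step from compound 2 to compound 3 in this assay is a 1.1-fold higher number from compound 2 to compound 3 (0.04 log units; within the scatter), that is, nothing beyond the scatter in either direction, with a wide range to reflect how little is known. Compound 3 is therefore estimated to give 40000 nM in this assay, within a range from 15000 nM to 120000 nM.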

Compound 3, concentration for 50% growth inhibition: > 100000 nM
Compound 3 ended at the assay's limit (the forecaster's own chance of this, stated with the estimate: 20%); middle value at least 2.5-fold (0.39 log units) from the limit.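

In this assay compound 3 gives > 100000 nM, which is a limit of the assay and not a number. Putting 4-hydroxybutyl in place of phenyl on a saturated chain carbon bound to a nitrogen on an aromatic ring gives an at least 2.7-fold higher number from compound 2 to compound 3 (0.43 log units; beyond the scatter), and putting 2-hydroxyethyl in place of phenyl on a saturated chain carbon, three bonds along the chain from a nitrogen on an aromatic ring, gives an at least 5.1-fold higher number from compound 1 to compound 3 (0.70 log units; beyond the scatter). Both steps lie beyond the scatter, so the end of this chain does matter for growth inhibition, which the two phenyl-ended compounds, too close to be told apart, could not show, and the true size of each step stays unknown, as the only firm reading is a bound: the limit of > 100000 nM in this assay, at which 1 of the 3 values shown sits.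

In compound 3 the phenyl ring leaves and a hydroxyl group arrives in a single change, so the compounds shown cannot say which of the two accounts for the loss of growth inhibition. A plain pentyl chain with no hydroxyl group would separate the two, and an amine at the chain end would show whether the phenyl ring can be replaced by another group at all.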